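Lengthening the amide of a butoxy pyrazole carboxamide

The compounds below may be only part of what the source reports. "The series", "measured", "known", "first", "only" and "open" are said of these compounds alone.

Three compounds from this series have been run in a functional assay on the whole organism (strain Wistar) for inhibition, with Rattus norvegicus as the target, read by paw edema, with stated times of 30 min and 3 h, at a dose of 100 mg/kg by the oral route; a higher number here means more inhibition at the dose given (going by the name of the read-out), a lower number less inhibition. Compound 1 `COc1cc(C(=O)N(C)C)nn1-c1ccccc1` gives 47.5%, and compound 2 `CCOc1cc(C(=O)N(C)C)nn1-c1ccccc1` gives 65.8%. Compound 3 `CCCCOc1cc(C(N)=O)nn1-c1ccccc1` gives 26.5%, the lowest of the three numbers, beyond the scatter below both others. Among the compounds with values here, the one measured single-point step, a number 18.3 percentage points higher from compound 1 to compound 2 (beyond the scatter), concerns the chain on the aromatic oxygen, not the amide.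

Compound 4 `CCCCOc1cc(C(=O)N(C)C)nn1-c1ccccc1` is the next compound to be measured. Its difference from compound 3 is dimethylamino in place of amino on a carbonyl carbon. No measured step among these compounds changes an amino group to a dimethylamino group, so the size of this step cannot be read off directly. What can be said is that compound 1 and compound 2, both carrying the dimethylcarbamoyl group, sit well above compound 3 in this assay, though each also differs from compound 3 in the chain on the oxygen. On that basis the step of a number 18.5 percentage points higher from compound 3 to compound 4 (beyond the scatter) is expected to run upward, with wide uncertainty. Compound 4 is therefore estimated at 45%, within a range from 22% to 68%.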

Compound 4, a percentage reported as inhibition, in the whole organism at one dose (the size of the read-out at that dose, not a potency): 18.7%
Estimate against measurement, compound 4: 26.3 percentage points above; measured number below the stated range.
By their numbers in this assay, from the lowest: compounds 4 and 3 (each within the scatter of the next); then compound 1; then compound 2.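

In this assay, replacing amino with dimethylamino on the carbonyl carbon gives a number 7.8 percentage points lower from compound 3 to compound 4 (within the scatter), so with the butoxy chain in place, the change from carbamoyl to dimethylcarbamoyl has no effect that this read-out can separate from the scatter. With dimethylcarbamoyl held constant, the chain on the oxygen now shows a clear drop at the butoxy end: propyl in place of hydrogen on the saturated chain carbon bound to the oxygen gives a number 28.8 percentage points lower from compound 1 to compound 4 (beyond the scatter), and ethyl in place of hydrogen two bonds along the chain from the oxygen gives a number 47.1 percentage points lower from compound 2 to compound 4 (beyond the scatter), so the number does not simply follow chain length, since compound 2 stands above compound 1 and compound 4 stands below both. Nothing available here accounts for either the flat amide step or this fall along the chain.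

From the compounds shown here alone, whether carbamoyl and dimethylcarbamoyl would also stay within the scatter of each other on the shorter chains of compound 1 and compound 2 remains open. Also open, going by these compounds, is how a propoxy chain on the oxygen, or methylamino on the carbonyl carbon, would read in this assay.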